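The source may report more compounds than this note shows. Statements on the series, on what has been measured and on what is new or still open speak of the compounds shown alone.

Compound 1 `CC(=O)N[C@@H]1CCC[C@H](C(=O)Nc2cc(-c3cnn(C)c3C)c(Cl)cn2)C1` and compound 2 `CC(=O)N[C@@H]1CCC[C@H](C(=O)Nc2cc(-c3nnn4ccccc34)c(Cl)cn2)C1` share one core and differ only in the group attached to an aromatic carbon. For the measured compounds named here, in a physicochemical assay for lipophilicity, using the shake flask method, measured as octanol-water partition, at pH 7.4 (on this read-out lower numbers stand for lower lipophilicity and higher numbers for higher lipophilicity), compound 1 gives 2.6, the higher of the two numbers known, and compound 2 gives 2. The measured step is a number 0.60 log units lower from compound 1 to compound 2 (beyond the scatter). Compound 3 `CC(=O)N[C@@H]1CCC[C@H](C(=O)Nc2cc(-c3cnn4c3CN(C)CC4)c(Cl)cn2)C1` carries a different replacement at that carbon: a group of 10 heavy atoms (7 carbon, 3 nitrogen; one five-membered aromatic ring with 2 hetero atoms, one six-membered non-aromatic ring with 2 hetero atoms) in place of a group of 7 heavy atoms (5 carbon, 2 nitrogen; one five-membered aromatic ring with 2 hetero atoms), on an aromatic carbon. Going by the values given here, only the step from compound 1 to compound 2 bears on this change; there, a larger group with an added ring in this place went with a modest fall in this assay. Compound 3 likewise brings a larger group with an added ring, so a fall of similar or somewhat greater size is expected, and the step is estimated as a number 1.00 log units lower from compound 1 to compound 3 (beyond the scatter). Compound 3 is therefore expected to give 1.6 in this assay, with a likely range from 0.9 to 2.3.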

Compound 3, distribution coefficient: 2.1
Compound 3: the middle estimate sits 0.50 log units below what was measured, within the range that was stated.
By their numbers in this assay, from the lowest: compounds 2 and 3 (each within the scatter of the next); then compound 1.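

With a second replacement in hand, both larger two-ring groups at this carbon give lower numbers in this assay than the 1,5-dimethyl-1H-pyrazol-4-yl group does (the new case: a number 0.50 log units lower from compound 1 to compound 3 (beyond the scatter)), so the fall seen for compound 2 is no longer a single case. The second ring need not be aromatic for this fall to appear: the two replacements differ in that ring, yet they cannot be told apart in this assay (a number 0.10 log units higher from compound 2 to compound 3 (within the scatter)). Nothing available explains these numbers.

Still open, from the compounds shown here alone, is whether the fall depends on a second ring at all, or would also come with a single ring of similar size. Also open, going by these compounds, is how a group carrying a carboxylic acid, or an amine on a longer chain, would compare at this carbon.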